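The source may report more compounds than this note shows. Statements on the series, on what has been measured and on what is new or still open speak of the compounds shown alone.

Compound 1 `CCN1CCC(CC(=O)NC2(c3ccc(Cl)c(Cl)c3)C(=O)Nc3cc(Cl)cc(Cl)c32)CC1` gives 3 nM in an in vitro assay on CHO-CREluc cells for displacement of a labelled ligand from growth hormone secretagogue receptor type 1 (Homo sapiens), read by scintillation counting, with a stated time of 1 h; on this read-out lower numbers stand for stronger inhibition and higher numbers for weaker inhibition. Compound 2 `C=CCN1CCN(CC(=O)NC2(c3ccc(Cl)c(Cl)c3)C(=O)Nc3cc(Cl)cc(Cl)c32)CC1` gives 121 nM in this assay, and compound 3 `CCN1CCN(CC(=O)NC2(c3ccc(Cl)cc3)C(=O)Nc3cc(Cl)c(Cl)cc32)CC1` gives 202 nM. Compound 2 thus holds the second highest of the three numbers, within the scatter of compound 3 and well beyond the scatter from compound 1. Among the compounds with values here, the only single-place step recorded is a 40-fold higher number from compound 1 to compound 2 (1.61 log units; beyond the scatter), a swap of 4-allylpiperazin-1-yl for 1-ethylpiperidin-4-yl on a saturated chain carbon bound to a carbonyl carbon. Compound 4 `CCN1CCN(CC(=O)NC2(c3ccc(Cl)c(Cl)c3)C(=O)Nc3cc(Cl)cc(Cl)c32)CC1` differs from compound 2 by methyl in place of vinyl on a saturated chain carbon bound to an amine nitrogen in a ring. Within the data shown here, no measured step touches this part of the molecule, so no shift beyond the scatter is expected. Compound 4 is therefore estimated at 120 nM, in the range 50 nM to 300 nM. The expected step is a 1.0-fold lower number from compound 2 to compound 4 (0.00 log units; within the scatter).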

Compound 4, inhibition constant: 8 nM
The estimate for compound 4 lay 15-fold (1.18 log units) above the measured number; measured number outside the range, below it.
By their numbers in this assay, from the lowest: compound 1; then compound 4; then compounds 2 and 3 (each within the scatter of the next).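

In this assay, the small change from allyl to ethyl, methyl in place of vinyl on a saturated chain carbon bound to an amine nitrogen in a ring, gives a 15-fold lower number from compound 2 to compound 4 (1.18 log units; beyond the scatter), so this position responds strongly. With ethyl kept, changing 1-ethylpiperidin-4-yl to 4-ethylpiperazin-1-yl gives only a 2.7-fold higher number from compound 1 to compound 4 (0.43 log units; beyond the scatter), so most of a 40-fold higher number from compound 1 to compound 2 (1.61 log units; beyond the scatter) goes with allyl rather than with that ring change. No measurement here explains the gap between allyl and ethyl.

A saturated propyl group in this place would help separate the effect of chain length from that of the double bond. From the compounds shown here alone, how a branched isopropyl group would read also remains open.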